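Shrinking the Ring That Carries the Carbamoyl Group

The source may report more compounds than this note shows. Statements on the series, on what has been measured and on what is new or still open speak of the compounds shown alone.

Of the compounds shown here, three built on one shared core have been tested in an assay on isolated protein for inhibition of protein kinase C theta type (Homo sapiens), read by TR-FRET, with a stated time of 2 h; a higher number here means a weaker inhibitor, a lower number a stronger inhibitor. Compound 1 `N#Cc1cnc(NCc2cnccc2C(F)(F)F)cc1NC[C@H]1CC[C@@H](O)CC1` gives 58 nM. Compound 2 `N#Cc1cnc(NCc2cnccc2C(F)(F)F)cc1NC1CCOCC1` gives 900 nM, and compound 3 `N#Cc1cnc(NCc2cnccc2C(F)(F)F)cc1N[C@H]1CC[C@@H](C(N)=O)CC1` gives 7 nM. Compound 3 thus has the lowest number of the three, and both steps toward it lie beyond the usual scatter: an 8.3-fold lower number from compound 1 to compound 3 (0.92 log units; beyond the scatter) and a 130-fold lower number from compound 2 to compound 3 (2.11 log units; beyond the scatter). The step of a 16-fold higher number from compound 1 to compound 2 (1.19 log units; beyond the scatter) shows how strongly the group on this nitrogen can move the result in this assay.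

Compound 4 `CC1(C)[C@@H](C(N)=O)C[C@H]1Nc1cc(NCc2cnccc2C(F)(F)F)ncc1C#N` has not yet been measured. It differs from compound 3 in one place: 3-carbamoyl-2,2-dimethylcyclobutyl in place of 4-carbamoylcyclohexyl on a nitrogen on an aromatic ring. The carbamoyl group is kept, but the ring that carries it changes from six-membered to four-membered with two methyl groups added. Among the compounds with values here, none of the measured steps tests a change of ring size with the carbamoyl group retained, so the direction is uncertain. Compound 3 reached 7 nM with the whole 4-carbamoylcyclohexyl group, so a modest loss seems more likely than a gain. For compound 4 the expected step is a 2.9-fold higher number from compound 3 to compound 4 (0.46 log units; beyond the scatter). The estimate for compound 4 in this assay is 20 nM, with a range from 5 nM to 80 nM.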

Compound 4, half-maximal inhibitory concentration: 1.4 nM
Compound 4: the middle estimate sits 14-fold (1.15 log units) above what was measured; the whole stated range lies above it.
By their numbers in this assay, from the lowest: compound 4; then compound 3; then compound 1; then compound 2.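

In this assay, the six-membered carbon ring gives way to a four-membered one bearing two methyl groups, with the same count of heavy atoms and the carbamoyl group kept, and the result is a 5.0-fold lower number from compound 3 to compound 4 (0.70 log units; beyond the scatter) rather than a loss. The same group also stands well clear of the other two groups tested on this nitrogen, with a 41-fold lower number from compound 1 to compound 4 (1.62 log units; beyond the scatter) and a 640-fold lower number from compound 2 to compound 4 (2.81 log units; beyond the scatter) in the same assay. So the low numbers do not depend on the whole 4-carbamoylcyclohexyl group, and among these four compounds the two that carry a carbamoyl group give the two lowest numbers, whichever ring holds it.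

Ring size and the two methyl groups changed together, so the compounds shown cannot separate their shares in this step, and neither a cyclobutyl ring without the methyl groups nor a carboxylic acid or an amine in place of the carbamoyl group is among them to test it. No measurement is available that would explain why this four-membered ring gives the lower number.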